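Para substituent swap on a boronate chalcone: nitro for methylsulfanyl

A few compounds are considered here, and "the series" means these few. Any claim that something is new, unique, unknown or untested is made for them only; others in the source may bear on it.

Three analogues sharing one core have been measured in a toxicity assay on WI-38 cells (Homo sapiens) for cytotoxicity, read by MTT assay, with a stated time of 48 h; on this read-out lower numbers stand for stronger inhibition and higher numbers for weaker inhibition. Compound 1 `O=C(/C=C/c1ccc2c(c1)B(O)OC2)c1ccc(-c2ccccc2)cc1` gives 18300 nM, compound 2 `O=C(/C=C/c1ccc2c(c1)B(O)OC2)c1ccc(F)cc1` gives 7600 nM, and compound 3 `CSc1ccc(C(=O)/C=C/c2ccc3c(c2)B(O)OC3)cc1` gives 54300 nM, the highest of the three numbers. The next analogue, compound 4 `O=C(/C=C/c1ccc2c(c1)B(O)OC2)c1ccc([N+](=O)[O-])cc1`, differs from compound 3 by nitro in place of methylsulfanyl on an aromatic carbon. Among the compounds with values here, the steps that bear on this change are a 3.0-fold higher number from compound 1 to compound 3 (0.47 log units; beyond the scatter) and a 7.1-fold higher number from compound 2 to compound 3 (0.85 log units; beyond the scatter), both showing that replacing the methylsulfanyl group moved the number down. Within the data shown here, no measured step involves nitro, so the direction rests on those two alone. Compound 4 is therefore expected to show a modest downward step, a 3.6-fold lower number from compound 3 to compound 4 (0.56 log units; beyond the scatter). Compound 4 is estimated at 15000 nM, within 5000 nM to 45000 nM.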

Compound 4, half-maximal inhibitory concentration: 39300 nM
Compound 4: the middle estimate sits 2.6-fold (0.42 log units) below what was measured, within the range that was stated.
By their numbers in this assay, from the lowest: compound 2; then compound 1; then compounds 4 and 3 (each within the scatter of the next).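

In this assay, the number does not separate nitro from methylsulfanyl at this position, on an aromatic carbon para to a large group: a 1.4-fold lower number from compound 3 to compound 4 (0.14 log units; within the scatter). Replacing methylsulfanyl therefore does not by itself bring the number down to the level of the fluoro or phenyl compounds, since there is a 5.2-fold higher number from compound 2 to compound 4 (0.71 log units; beyond the scatter) and a 2.1-fold higher number from compound 1 to compound 4 (0.33 log units; beyond the scatter). Nothing available here accounts for this outcome. From the compounds shown here alone, whether an amine or a carboxylic acid at this position would sit nearer fluoro or nitro remains open, as does the outcome for a longer chain.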